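Compound 3: expected exposure after a side-chain swap

This account rests on a few compounds, and the source may have more. Where it says the series, first, only, none or still open, it means among the compounds named here.

Compound 1 (`c1cc([C@H]2CC[C@]3(CC2)OOC2(O3)C3CC4CC(C3)CC2C4)ccc1OCCC1CCNCC1`) gives 16000 ng.h/mL
Compound 2 (`CC1(C)CC(O)(COc2ccc([C@H]3CC[C@]4(CC3)OOC3(O4)C4CC5CC(C4)CC3C5)cc2)CC(C)(C)N1`) gives 17300 ng.h/mL

Compound 2 stands level with compound 1 in an ADME assay on the whole organism (strain FVB) for pharmacokinetics, with Mus musculus as the target, read by LC-MS, at a dose of 30 mg/kg by the oral route; on this read-out higher numbers stand for higher exposure at the dose given and lower numbers for lower exposure. Within the data shown here, the only measured step shows a 1.1-fold higher number from compound 1 to compound 2 (0.03 log units; within the scatter) and so the two cannot be told apart.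

Compound 3 (`O[C@H]1CC[C@H](NCCCOc2ccc([C@H]3CC[C@]4(CC3)OOC3(O4)C4CC5CC(C4)CC3C5)cc2)CC1`) keeps the shared core but carries 2-((4-hydroxycyclohexyl)amino)ethyl in place of 4-hydroxy-2,2,6,6-tetramethylpiperidin-4-yl on a saturated chain carbon bound to an oxygen on an aromatic ring . Among the measured compounds shown here, that one measured step exchanged a different pair of groups, and no measured compound carries the entering group, so it offers only loose guidance. No step beyond the scatter is expected in this assay, though with real uncertainty. The estimated step is a 1.4-fold lower number from compound 2 to compound 3 (0.16 log units; within the scatter) on this evidence. For compound 3 the estimated value is 12000 ng.h/mL, with an expected range from 4000 ng.h/mL to 35000 ng.h/mL in repeat measurements.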

Compound 3, area under the concentration-time curve: 6570 ng.h/mL
Estimate against measurement, compound 3: 1.8-fold (0.26 log units) above; low and high end bracket the measured number.
By their numbers in this assay, from the lowest: compound 3; then compounds 1 and 2 (each within the scatter of the next).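

In this assay, this position turns out not to be indifferent to what it carries: changing the side chain gives a 2.6-fold lower number from compound 2 to compound 3 (0.42 log units; beyond the scatter), a step the earlier pair did not show. Set against the side chain of compound 1, the same entering group gives a 2.4-fold lower number from compound 1 to compound 3 (0.39 log units; beyond the scatter), so the two side chains with their nitrogen in the ring stand level with each other, and the side chain with its nitrogen in the open chain and a ring of carbon only stands lower. Nothing measured here explains this fall in exposure.

The change moves the nitrogen out of the ring and brings in the 4-hydroxycyclohexyl group at once, and the compounds shown do not separate these two parts. A plain open-chain amine such as dimethylamino on the same chain, or a piperazine ring, would speak to that question.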